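The compounds below may be only part of what the source reports. "The series", "measured", "known", "first", "only" and "open" are said of these compounds alone.

In a functional assay on MOLT-4 cells (Homo sapiens) for inhibition, read by sulforhodamine B assay, with a stated time of 48 h (on this read-out lower numbers stand for stronger inhibition of growth and higher numbers for weaker inhibition of growth), two compounds have been measured:

compound 1 `Nc1cc(N)c2nc(-c3ccccc3)c(NCc3ccc(Cl)c(Cl)c3)nc2c1` gives 2090 nM
compound 2 `COc1ccc(CNc2nc3cc(N)cc(N)c3nc2-c2ccccc2)cc1OC` gives 3470 nM

Among the compounds with values here, of these two numbers, that of compound 2 is the larger, but the single step between them, a 1.7-fold higher number from compound 1 to compound 2 (0.22 log units; within the scatter), lies within the scatter and so does not truly set the two apart.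

Compound 3 `COc1cc(CNc2nc3cc(N)cc(N)c3nc2-c2ccccc2)cc(OC)c1OC` has not been measured. It differs from compound 2 in one place: methoxy in place of hydrogen on an aromatic carbon.

Within the data shown here, no measured step adds a group to the ring that already carries two methoxy groups. Among the measured compounds shown here, the only step available, a 1.7-fold higher number from compound 1 to compound 2 (0.22 log units; within the scatter), exchanges the whole ring and itself stays within the scatter, so it offers no direction for this smaller change. The step this estimate implies, a 1.0-fold higher number from compound 2 to compound 3 (0.00 log units; within the scatter), is therefore expected to stay within the scatter. Compound 3 is estimated at 3500 nM, with a range from 1500 nM to 8000 nM.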

Compound 3, concentration for 50% growth inhibition: 12300 nM
Estimate against measurement, compound 3: 3.5-fold (0.55 log units) below, outside the stated range (above it).
By their numbers in this assay, from the lowest: compounds 1 and 2 (each within the scatter of the next); then compound 3.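

In this assay, within the data shown here, adding a methoxy group on the aromatic carbon ortho to one methoxy group and meta to another gives a 3.5-fold higher number from compound 2 to compound 3 (0.55 log units; beyond the scatter), the first step here that lies beyond the scatter. A higher number means weaker inhibition of growth, so this single addition to the ring of compound 2 costs more than exchanging the whole substituted ring did, which gave only a 1.7-fold higher number from compound 1 to compound 2 (0.22 log units; within the scatter). Nothing measured here explains why the added methoxy group weakens growth inhibition.

From the compounds shown here alone, how a hydroxy group or a fluorine atom on this same carbon would compare with methoxy remains open. Going by these compounds, it is also open whether the loss comes from this one carbon alone or depends on the two methoxy groups already on the ring.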